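Amide nitrogen change from compound 3 to compound 4

The source may hold more compounds than are shown below. What is called first, only, known or untested is meant among the compounds shown, and "the series" means these compounds.

- compound 1 `CN(C)C(=O)Cn1c(-c2ccc(F)cc2)nc2cccnc21`: 40.5 mg/kg
- compound 2 `CN(C)C(=O)Cn1c(-c2ccco2)nc2cccnc21`: > 100 mg/kg (a limit of the assay)
- compound 3 `CNC(=O)Cn1c(-c2ccc(Cl)cc2)nc2cccnc21`: 12.5 mg/kg
- compound 4 `CCCN(C)C(=O)Cn1c(-c2ccc(Cl)cc2)nc2cccnc21`: not yet measured

In a functional assay on the whole organism with Mus musculus as the target (on this read-out lower numbers stand for an effect already at smaller amounts and higher numbers for an effect only at larger amounts of compound), compound 3 gives 12.5 mg/kg, the lowest number shown, and compound 1 gives 40.5 mg/kg; this gap lies beyond the scatter. Compound 4 carries propyl in place of hydrogen on an amide-type nitrogen. Among the compounds with values here, the only measured step, an at least 2.4-fold higher number from compound 1 to compound 2 (0.39 log units; beyond the scatter), lies on an aromatic carbon, so it bears only indirectly. It ends at the limit of > 100 mg/kg in this assay, at which 1 of the 3 values shown sits. Compound 1 at 40.5 mg/kg also lacks the amide hydrogen but differs elsewhere too, so it offers only a weak hint. A modest rise in this assay is therefore expected, with the expected step being a 2.0-fold higher number from compound 3 to compound 4 (0.30 log units; within the scatter). The estimated value for compound 4 is 25 mg/kg, with an expected range of 8 mg/kg to 80 mg/kg.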

Compound 4, dose for half-maximal effect: 11.6 mg/kg
Compound 4: the middle estimate sits 2.2-fold (0.33 log units) above what was measured; low and high end bracket the measured number.
By their numbers in this assay, from the lowest: compounds 4 and 3 (each within the scatter of the next); then compound 1. At a limit, above all of these: compound 2.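

In this assay, the step with propyl in place of hydrogen on the amide-type nitrogen is a 1.1-fold lower number from compound 3 to compound 4 (0.03 log units; within the scatter) and shows no loss, so the amide hydrogen is not required for the effect in this pair. Within the data shown here, compound 1 also lacks that hydrogen but differs elsewhere, which makes this pair the first direct reading of this position. Nothing on hand explains why this nitrogen accepts propyl.

Still open, going by these compounds, is whether a longer chain, a benzyl group or a chain ending in a carboxylic acid would fare the same on this nitrogen.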